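A few compounds are considered here, and "the series" means these few. Any claim that something is new, unique, unknown or untested is made for them only; others in the source may bear on it.

The measured compounds:
compound 1, `CCS(=O)(=O)N(Cc1cccnc1)c1ccc(C(=O)c2ccccc2)cc1`: 4200 nM
compound 2, `C=C(c1ccccc1)c1cccc(N(Cc2cccnc2)S(=O)(=O)CC)c1`: 200 nM

In an assay on isolated protein with metabotropic glutamate receptor 2 (Homo sapiens) as the target (on this read-out lower numbers stand for an effect already at smaller amounts and higher numbers for an effect only at larger amounts of compound), compound 1 gives 4200 nM, the higher of the two numbers. Compound 2 gives 200 nM, and the gap between these two values lies beyond the usual scatter. These two compounds differ in more than one place, so nothing can be drawn from them about any single change.

Compound 3, `CCS(=O)(=O)N(Cc1cccnc1)c1ccc(Cc2ccccc2)cc1`, has not yet been measured. It differs from compound 1 in one place: benzyl in place of benzoyl on an aromatic carbon. Among the compounds with values here, no pair of measured compounds shows a step of this kind, so there is no direct guide to its size or direction. In that absence, the expected step from compound 1 to compound 3 is a 1.2-fold higher number from compound 1 to compound 3 (0.08 log units; within the scatter), small enough to sit within the scatter in either direction. For compound 3 in this assay the estimate is 5000 nM, with a range from 1500 nM to 16000 nM.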

Compound 3, half-maximal effective concentration: 1600 nM
Beside the measured number, compound 3's estimate is 3.1-fold (0.49 log units) above it; measured number inside the range.
By their numbers in this assay, from the lowest: compound 2; then compound 3; then compound 1.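

In this assay, putting benzyl in place of benzoyl on the aromatic carbon para to a large group gives a 2.6-fold lower number from compound 1 to compound 3 (0.42 log units; beyond the scatter). This shows that the number at this position responds to the swap, and that the carbonyl of benzoyl, with its hydrogen-bond acceptor, is not needed to retain the effect, since the number is lower without it. The data offer no measurement that explains the direction of this modest step.

Within the data shown here, with only this one pair, it remains open whether the lower number comes from losing the carbonyl oxygen or from some other difference between the two groups. An ether oxygen or a longer chain linking the two rings, or an amine on the outer ring, could help separate these possibilities.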